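The source may hold more compounds than are shown below. What is called first, only, known or untested is meant among the compounds shown, and "the series" means these compounds.

Measured compounds:
- Compound 1, `C#CCNC1CCc2c(SCCc3ccc(C)cc3)cccc21`, gives 4520 nM in an ADME assay on isolated protein for inhibition of Amine oxidase [flavin-containing] B (Homo sapiens); on this read-out higher numbers stand for weaker inhibition and lower numbers for stronger inhibition.
- Compound 2, `C#CCNC1CCc2c(SCCc3ccc(OC)cc3)cccc21`, gives 4590 nM in this assay.

Both measured compounds share the same core and differ only in the group carried on the chain beyond the sulfur. For the measured compounds named here, the one measured step, a 1.0-fold higher number from compound 1 to compound 2 (0.01 log units; within the scatter), shows that swapping methyl for methoxy on the aromatic ring left the read-out essentially unchanged. Compound 2 therefore stands level with compound 1; the two values lie within the scatter of each other, so neither can be called stronger or weaker.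

Compound 3, `C#CCNC1CCc2c(SCCc3ccc(Cl)c(Cl)c3)cccc21`, carries a different group: 3,4-dichlorophenyl in place of 4-methoxyphenyl on a saturated chain carbon, two bonds along the chain from a sulfur. Compound 3 is not yet measured in this assay. Going by the values given here, no measured step involves a chlorinated ring, so the only guide is that the one known change at this position, from compound 1 to compound 2, made no difference beyond the scatter. On that basis the step from compound 2 to compound 3 is expected to be small, a 1.3-fold lower number from compound 2 to compound 3 (0.12 log units; within the scatter), with no clear direction. Compound 3 is accordingly estimated at 3500 nM, with a range from 1000 nM to 12000 nM.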

Compound 3, half-maximal inhibitory concentration: 2820 nM
Estimate against measurement, compound 3: 1.2-fold (0.09 log units) above, and the stated range covers the measured number.
By their numbers in this assay, from the lowest: compounds 3, 1 and 2 (each within the scatter of the next).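

In this assay, putting 3,4-dichlorophenyl in place of 4-methoxyphenyl gives a 1.6-fold lower number from compound 2 to compound 3 (0.21 log units; within the scatter), and putting it in place of 4-methylphenyl gives a 1.6-fold lower number from compound 1 to compound 3 (0.20 log units; within the scatter). The earlier pair compared only a methyl and a methoxy group on the ring, whereas this change brings in two chlorine atoms and removes the one hydrogen-bond acceptor counted in 4-methoxyphenyl, yet all three compounds still lie within the scatter of each other and cannot be ranked. At this place on the chain, three differently substituted phenyl rings therefore give read-outs that cannot be told apart, although no measurement here explains why this is so.

Whether any group at this place can move the number beyond the scatter remains open, since every compound shown carries a substituted phenyl ring there. The compounds shown give no information on how an amine, a carboxylic acid or a longer chain at this place would read in this assay.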